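The source may report more compounds than this note shows. Statements on the series, on what has been measured and on what is new or still open speak of the compounds shown alone.

Measured compounds:
compound 1 `ClCc1ccccc1Cn1cnc2c(Cl)nc(Cl)nc21`, 3380 nM
compound 2 `ClCc1ccccc1Cn1cnc2c(Cl)ncnc21`, 12600 nM
compound 3 `ClCc1ccc(Cn2cnc3nc(Cl)nc(Cl)c32)cc1`, 3890 nM

All three were tested in a functional assay on NCI-H226 cells (Homo sapiens) for cytotoxicity, read by sulforhodamine B assay, with a stated time of 48 h; on this read-out higher numbers stand for weaker inhibition of growth and lower numbers for stronger inhibition of growth. Compound 1 and compound 2 differ by one change, (hydrogen in place of chloro on an aromatic carbon), and this change gave a 3.7-fold higher number from compound 1 to compound 2 (0.57 log units; beyond the scatter). Compound 3 shares its atoms with compound 1 but they are joined differently; the difference between the two cores is not broken down here. Their values lie close together, within the usual scatter.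

Compound 4 `ClCc1ccc(Cn2cnc3ncnc(Cl)c32)cc1` is related to compound 3 by hydrogen in place of chloro on an aromatic carbon, the same change as that from compound 1 to compound 2, at the same kind of place. If it behaves the same way, the step from compound 3 to compound 4 is expected to be about a 3.6-fold higher number from compound 3 to compound 4 (0.56 log units; beyond the scatter), because the earlier step was a 3.7-fold higher number from compound 1 to compound 2 (0.57 log units; beyond the scatter). Compound 4 is therefore estimated at 14000 nM, likely between 7000 nM and 30000 nM.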

Compound 4, concentration for total growth inhibition: 12000 nM
The estimate for compound 4 lay 1.2-fold (0.07 log units) above the measured number, and the stated range covers the measured number.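

Putting hydrogen in place of the chloro group on the core of compound 3 weakened growth inhibition in this assay, with a 3.1-fold higher number from compound 3 to compound 4 (0.49 log units; beyond the scatter). The change carried over between the two cores with steps of matching size: the same change on two cores in this assay, a 3.7-fold higher number (0.57 log units; beyond the scatter) from compound 1 to compound 2 and a 3.1-fold higher number (0.49 log units; beyond the scatter) from compound 3 to compound 4, 1.2-fold (0.08 log units) apart, within the scatter of two such steps. Among the compounds shown here, with only two pairs in a single cell line, this shows agreement for these two cores, but it does not show that the step would hold on other cores or in other assays.

On these data alone, only chloro and hydrogen are seen at this place, so the effect of an amine or a methoxy group there stays open. Also open, as far as these compounds go, is what would happen if the remaining chloro group in compound 2 and compound 4 gave way to hydrogen or an amine.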